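A few compounds are considered here, and "the series" means these few. Any claim that something is new, unique, unknown or untested is made for them only; others in the source may bear on it.

Measured so far:
compound 1 `COc1cc(Cc2nc3c(N)ncnc3n2CC2CCCO2)cc(OC)c1OC` — 91200 nM
compound 2 `CCCn1c(Cc2cc(OC)c(OC)c(OC)c2)nc2c(N)nc(F)nc21` — 25100 nM

In a functional assay on MCF7 cells (Homo sapiens) for antiproliferative activity (a lower number here means a stronger inhibitor, a higher number a weaker inhibitor), compound 1 gives 91200 nM, the higher of the two numbers recorded; compound 2 gives 25100 nM, and the gap between them is beyond the usual scatter. Compound 3 `COc1cc(Cc2nc3c(N)ncnc3n2CC2CCC2)cc(OC)c1OC` has not yet been measured. It differs from compound 1 in one place: cyclobutyl in place of oxolan-2-yl on a saturated chain carbon bound to an aromatic nitrogen. Among the measured compounds shown here, no measured pair differs only in this way, so the size of the step is not anchored by any recorded one. Both measured numbers sit in the weak range, with compound 1 at the weaker end, and nothing recorded points firmly in either direction; the step from compound 1 to compound 3 is expected to be a 1.3-fold lower number from compound 1 to compound 3 (0.11 log units; within the scatter), small and probably within or near the scatter. For compound 3 the estimate is 70000 nM, with a range from 25000 nM to 200000 nM.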

Compound 3, half-maximal inhibitory concentration: 45700 nM
Estimate against measurement, compound 3: 1.5-fold (0.19 log units) above, within the range that was stated.
By their numbers in this assay, from the lowest: compounds 2, 3 and 1 (each within the scatter of the next, the first and the last beyond it).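

Cyclobutyl in place of oxolan-2-yl on a saturated chain carbon bound to an aromatic nitrogen gives, in this assay, a 2.0-fold lower number from compound 1 to compound 3 (0.30 log units; within the scatter). Among the compounds shown here, this is the first step at this position that rests on two measured compounds, and it shows that exchanging the five-membered ring with its one oxygen and one hydrogen-bond acceptor for the four-membered carbon ring leaves the number within the scatter. Nothing available bears on why the step has this size.

Only these two ring groups can be compared here, so one step says little about the range of groups this position accepts. On these data alone, whether an amine such as piperidin-4-yl, a carboxylic acid or a longer chain such as butyl on the same carbon would separate from compound 1 beyond the scatter remains open.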